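Swapping Fluoro for Chloro on the Benzyl Ring

The source may report more compounds than this note shows. Statements on the series, on what has been measured and on what is new or still open speak of the compounds shown alone.

Measured compounds:
compound 1, `O=C(CCC1=CCN(CCCc2ccc(Cl)cc2)C1=O)NO`, 2210 nM
compound 2, `O=C(CCC1=CCN(Cc2ccc(F)cc2)C1=O)NO`, 1940 nM

In a functional assay on MDA-MB-231 cells (Homo sapiens) for inhibition, read by sulforhodamine B assay (a higher number here means a weaker inhibitor of growth, a lower number a stronger inhibitor of growth), compound 1 gives 2210 nM and compound 2 gives 1940 nM. Compound 2 stands at the lower of the two numbers, yet the two lie within the scatter of each other, so neither can be called the stronger. Compound 3 `O=C(CCC1=CCN(Cc2ccc(Cl)cc2)C1=O)NO` differs from compound 2 in one place: chloro in place of fluoro on an aromatic carbon. For the measured compounds named here, no measured pair shows this change. A step from compound 2 to compound 3 beyond the scatter is not expected in either direction. Compound 3 is estimated at 1900 nM, with a range from 900 nM to 4000 nM. This means an expected step of a 1.0-fold lower number from compound 2 to compound 3 (0.01 log units; within the scatter).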

Compound 3, concentration for 50% growth inhibition: 1990 nM
Estimate against measurement, compound 3: 1.0-fold (0.02 log units) below; low and high end bracket the measured number.
By their numbers in this assay, from the lowest: compounds 2, 3 and 1 (each within the scatter of the next).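

In this assay, for the compounds shown here, chloro in place of fluoro on an aromatic carbon para to a large group gives a 1.0-fold higher number from compound 2 to compound 3 (0.01 log units; within the scatter), the only comparison here in which this halogen alone differs. At this position, then, the two halogens cannot be told apart in this growth read-out, something compounds 1 and 2 could not show, as they also differ in their chain. No measurement here bears on why this is so. Still open, on these data alone, is whether a methoxy group, an amine or a carboxylic acid on the same carbon would read differently from either halogen.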